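Anilino in place of methyl(pyridin-3-yl)amino

The source may hold more compounds than are shown below. What is called first, only, known or untested is meant among the compounds shown, and "the series" means these compounds.

Compounds measured so far in a physicochemical assay for solubility, read by LC-MS, in phosphate buffer, with a stated time of 24 h, at pH 7.4 (on this read-out lower numbers stand for lower solubility and higher numbers for higher solubility), are these
- compound 1 `COCCC(=O)Nc1cnc(NCc2c(F)ccc3c2CCO3)n2cnnc12` gives 980000 nM
- compound 2 `CN(c1ccn(C)n1)c1cnc(NCc2c(F)ccc3c2CCO3)n2cnnc12` gives 130000 nM
- compound 3 `CN(c1cccnc1)c1cnc(NCc2c(F)ccc3c2CCO3)n2cnnc12` gives 47000 nM

Compound 3 (47000 nM) holds the lowest of the three numbers, and both other compounds lie beyond the scatter from it. The next compound is compound 4 `Fc1ccc2c(c1CNc1ncc(Nc3ccccc3)c3nncn13)CCO2` with the change anilino in place of methyl(pyridin-3-yl)amino on an aromatic carbon as anilino in place of methyl(pyridin-3-yl)amino on an aromatic carbon. Among the measured compounds shown here, no measured step makes this exact change. The closest is the modest step on the same nitrogen (a 2.8-fold lower number from compound 2 to compound 3 (0.44 log units; beyond the scatter)), with pyridin-3-yl in place of 1-methyl-1H-pyrazol-3-yl. The two steps away from ((2-methoxyethyl)carbonyl)amino at this aromatic carbon are wider (a 7.5-fold lower number from compound 1 to compound 2 (0.88 log units; beyond the scatter) and a 21-fold lower number from compound 1 to compound 3 (1.32 log units; beyond the scatter)) and show that the number can move far with the group placed here. For the measured compounds named here, the data hold no step that removes only the methyl or only the ring nitrogen, so the direction rests on thin evidence. A modest step to a lower number is expected in this assay on this basis. The estimated step is a 3.1-fold lower number from compound 3 to compound 4 (0.50 log units; beyond the scatter) and remains an expectation. For compound 4 the expected value is 15000 nM with an estimated range from 3000 nM to 50000 nM in this series.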

Compound 4, solubility: 3000 nM
The estimate for compound 4 lay 5.0-fold (0.70 log units) above the measured number; measured number inside the range.
By their numbers in this assay, from the lowest: compound 4; then compound 3; then compound 2; then compound 1.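

At this aromatic carbon, in this assay, anilino in place of methyl(pyridin-3-yl)amino gives a 16-fold lower number from compound 3 to compound 4 (1.19 log units; beyond the scatter), a large step where the earlier exchange of one ring on the same nitrogen gave only a 2.8-fold lower number from compound 2 to compound 3 (0.44 log units; beyond the scatter). The other two routes to compound 4 are wider still, with a 43-fold lower number from compound 2 to compound 4 (1.64 log units; beyond the scatter) and a 330-fold lower number from compound 1 to compound 4 (2.51 log units; beyond the scatter), so compound 4 now marks the low end of the series and the range set by this one position is much greater than the first three compounds showed. The step removes the methyl, replaces the pyridine ring with a ring of carbon only and adds a hydrogen-bond donor all at once, and nothing available bears on why the number falls.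

From the compounds shown here alone, it remains open which part of the change carries the step: methyl(phenyl)amino and pyridin-3-ylamino at this carbon would each separate the ring nitrogen from the methyl. Also open, going by these compounds, is whether a morpholine or a carboxylic acid on the phenyl ring of compound 4 would move the number back towards that of compound 1.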